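A few compounds are considered here, and "the series" means these few. Any claim that something is new, unique, unknown or untested is made for them only; others in the source may bear on it.

In an in vivo ADME assay on the whole organism (strain Sprague-Dawley) for pharmacokinetics, with Rattus norvegicus as the target (on this read-out higher numbers stand for wider distribution into tissues and lower numbers for narrower distribution), compound 3 `CCCCCOC(=O)N1CCN(C(=O)[C@H](CCC(=O)O)NC(=O)c2cc(N3CCC(CNC)CC3)nc(-c3ccccc3)n2)CC1` gives 2 L/kg, the highest of the three numbers seen so far, with compound 1 `CCCCCOC(=O)N1CCN(C(=O)[C@H](CCC(=O)O)NC(=O)c2cc(N3CCC(COC)CC3)nc(-c3ccccc3)n2)CC1` nearest at 1.1 L/kg and compound 2 `CCCCCOC(=O)N1CCN(C(=O)[C@H](CCC(=O)O)NC(=O)c2cc(N3CCC(C(=O)N4CCCC4)CC3)nc(-c3ccccc3)n2)CC1` furthest away at 0.2 L/kg. Compound 4 `CCCCCOC(=O)N1CCN(C(=O)[C@H](CCC(=O)O)NC(=O)c2cc(N3CCC(C(N)=O)CC3)nc(-c3ccccc3)n2)CC1` carries carbamoyl in place of (methylamino)methyl on a saturated ring carbon. For the measured compounds named here, two measured steps bear on this change: a 10-fold higher number from compound 2 to compound 3 (1.00 log units; beyond the scatter) links a carbonyl-bearing group on the same saturated ring carbon to the (methylamino)methyl group, and a 1.8-fold higher number from compound 1 to compound 3 (0.26 log units; within the scatter) is the smaller companion step. Because compound 2 gives 0.2 L/kg with a carbonyl-bearing group in that position, a drop beyond the scatter is expected for compound 4, estimated as a 6.7-fold lower number from compound 3 to compound 4 (0.82 log units; beyond the scatter). Compound 4 is therefore expected to give 0.3 L/kg, within a range from 0.15 L/kg to 0.7 L/kg.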

Compound 4, volume of distribution at steady state: 2.4 L/kg
The estimate for compound 4 lay 8.0-fold (0.90 log units) below the measured number; the whole stated range lies below it.
By their numbers in this assay, from the lowest: compound 2; then compounds 1, 3 and 4 (each within the scatter of the next, the first and the last beyond it).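

In this assay, carbamoyl on this saturated ring carbon gives a 1.2-fold higher number from compound 3 to compound 4 (0.08 log units; within the scatter), so a carbonyl on that carbon does not by itself go with the low number of compound 2. On the carbonyl carbon, amino in place of pyrrolidin-1-yl gives a 12-fold higher number from compound 2 to compound 4 (1.08 log units; beyond the scatter), whereas carbamoyl in place of methoxymethyl gives the smaller 2.2-fold higher number from compound 1 to compound 4 (0.34 log units; beyond the scatter), which points to the pyrrolidin-1-yl amide rather than the carbonyl. No measurement here explains these steps. The compounds shown leave open whether a dimethylamino group on that carbonyl carbon would track compound 2 or compound 4. They also leave open how a carboxylic acid on the same ring carbon would compare.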